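Chloro for Fluoro: What to Expect of Compound 4

The source may hold more compounds than are shown below. What is called first, only, known or untested is meant among the compounds shown, and "the series" means these compounds.

Of the compounds shown here, three have so far been measured in a functional assay on L1210 cells (Mus musculus) for cytotoxicity, with a stated time of 48 h; on this read-out higher numbers stand for weaker inhibition and lower numbers for stronger inhibition. Compound 1 `O=C1/C(=C/c2ccc(F)cc2)CCC/C1=C\c1ccccc1[N+](=O)[O-]` gives 8400 nM. Compound 2 `O=C1/C(=C/c2ccc(F)cc2)CCC/C1=C\c1ccc([N+](=O)[O-])cc1` gives 26800 nM, and compound 3 `O=C1/C(=C/c2ccc(Cl)cc2)CCC/C1=C\c1ccc([N+](=O)[O-])cc1` gives 9410 nM. Compound 2 and compound 3 differ in a single place: chloro in place of fluoro on an aromatic carbon. That change made a 2.8-fold lower number from compound 2 to compound 3 (0.45 log units; beyond the scatter). Compound 1 and compound 2 are built from the same atoms joined differently; the difference between the two cores is not broken down here. Compound 1 and compound 3 lie within the usual scatter of each other, so no order can be read between them.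

Compound 4 `O=C1/C(=C/c2ccc(Cl)cc2)CCC/C1=C\c1ccccc1[N+](=O)[O-]` has not yet been measured. It differs from compound 1 by the same change as the one just described: chloro in place of fluoro on an aromatic carbon. Because that change gave a 2.8-fold lower number from compound 2 to compound 3 (0.45 log units; beyond the scatter), the step here is expected to be of similar size, a 2.1-fold lower number from compound 1 to compound 4 (0.32 log units; beyond the scatter), although one earlier example is a thin basis and the step may turn out smaller. On that basis compound 4 is expected to give 4000 nM in this assay, with a likely range from 1500 nM to 10000 nM.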

Compound 4, half-maximal inhibitory concentration: 9380 nM
Compound 4: the middle estimate sits 2.3-fold (0.37 log units) below what was measured, and the stated range covers the measured number.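

Fluoro and chloro do not show the same difference on the two cores. On the core of compound 1, the change gives a 1.1-fold higher number from compound 1 to compound 4 (0.05 log units; within the scatter) in this assay, so the lower number seen on the other core does not carry over. Set side by side, the two steps clearly disagree: the same change on two cores in this assay, a 2.8-fold lower number (0.45 log units; beyond the scatter) from compound 2 to compound 3 and a 1.1-fold higher number (0.05 log units; within the scatter) from compound 1 to compound 4, 3.2-fold (0.50 log units) apart, beyond the scatter of two such steps

This shows that, among these four compounds, the result of the change depends on the core it is made on, so a step measured on one core is a poor guide to the step on the other. It does not show why the two cores differ, and two pairs are too few to support a general rule for the series.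

The compounds shown leave open how a bromo, methoxy or amine group in the same place would behave on each core. They also leave open whether a group such as a nitrile in place of the nitro group would change the picture.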